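The source may report more compounds than this note shows. Statements on the series, on what has been measured and on what is new or still open speak of the compounds shown alone.

Compound 1, `O=C(c1ccccc1)N1CCC(NCCSC(c2ccc(F)cc2)c2ccc(F)cc2)CC1`, gives 4.51 nM in an assay on membranes from striatum (strain Sprague-Dawley) for displacement of a labelled ligand from sodium-dependent dopamine transporter (Rattus norvegicus), read by scintillation counting, with a stated time of 120 min; a lower number here means a stronger inhibitor, a higher number a weaker inhibitor. Compound 2, `O=C(c1ccccc1F)N1CCC(NCCSC(c2ccc(F)cc2)c2ccc(F)cc2)CC1`, gives 46.1 nM in this assay. Compound 3, `O=C(c1ccccc1F)N1CCC(NCC[S+]([O-])C(c2ccc(F)cc2)c2ccc(F)cc2)CC1`, gives 604 nM in this assay.

The change fluoro in place of hydrogen on an aromatic carbon brought a 10-fold higher number from compound 1 to compound 2 (1.01 log units; beyond the scatter). Compound 3 carries a different core from compound 1; the difference between the two cores is not broken down here, and compound 3 gives the highest number of the three. Compound 4, `O=C(c1ccc(F)cc1F)N1CCC(NCC[S+]([O-])C(c2ccc(F)cc2)c2ccc(F)cc2)CC1`, differs from compound 3 by fluoro in place of hydrogen on an aromatic carbon. This is the same kind of change as from compound 1 to compound 2, but the place differs: in compound 2 the fluoro is ortho to a large group, whereas in compound 4 it is meta to a fluoro group and para to a large group. The expected step is a 1.8-fold higher number from compound 3 to compound 4 (0.26 log units; within the scatter), resting on the weakening seen in a 10-fold higher number from compound 1 to compound 2 (1.01 log units; beyond the scatter) but tempered by the different place. The estimate for compound 4 is 1100 nM.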

Compound 4, inhibition constant: 564 nM
Estimate against measurement, compound 4: 2.0-fold (0.29 log units) above; measured number inside the range.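

On the core of compound 3, going from 2-fluorophenyl to 2,4-difluorophenyl gives a 1.1-fold lower number from compound 3 to compound 4 (0.03 log units; within the scatter), so the two compounds cannot be told apart in this assay. Fluoro in place of hydrogen on an aromatic carbon therefore cannot be counted on to have the same size of effect across these two cores: the same change on two cores in this assay, a 10-fold higher number (1.01 log units; beyond the scatter) from compound 1 to compound 2 and a 1.1-fold lower number (0.03 log units; within the scatter) from compound 3 to compound 4, 11-fold (1.04 log units) apart, beyond the scatter of two such steps

This does not show that the core alone sets the size of the step, as the fluoro also sits in a different place in each pair, and the share of core and of place cannot be read.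

Still open, on these data alone, is how a chloro or a methoxy group, para to a large group, would behave on the core of compound 3. Also open, as far as these compounds go, is what a fluoro in that same place would do on the core of compound 1.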